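The compounds below may be only part of what the source reports. "The series", "measured", "known", "first", "only" and "open" are said of these compounds alone.

Compound 2 `CSC(=O)N1CCC(Oc2ncnc3c2CCN3c2ccc(S(C)(=O)=O)cc2F)CC1` gives 251 nM in a functional assay on CHO-K1 cells for agonist activity at Glucose-dependent insulinotropic receptor (Homo sapiens), read by a luciferase reporter, with a stated time of 5 h (on this read-out higher numbers stand for an effect only at larger amounts of compound and lower numbers for an effect already at smaller amounts), and compound 1 `COC(=O)N1CCC(Oc2ncnc3c2CCN3c2ccc(S(C)(=O)=O)cc2F)CC1` gives 316 nM in this assay, the two numbers lying within the scatter of each other. Going by the values given here, the only measured step, a 1.3-fold lower number from compound 1 to compound 2 (0.10 log units; within the scatter), altered the group on the same carbonyl carbon. Compound 3 `CC(C)SC(=O)N1CCC(Oc2ncnc3c2CCN3c2ccc(S(C)(=O)=O)cc2F)CC1` differs from compound 2 in that (isopropyl in place of methyl on a sulfur). Among the compounds with values here, no measured step covers a change on that sulfur, and the one step nearby stayed within the scatter, so the step expected in this assay is a 1.0-fold lower number from compound 2 to compound 3 (0.00 log units; within the scatter), none beyond the scatter. Compound 3 is therefore estimated at 250 nM, with a range from 100 nM to 700 nM.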

Compound 3, half-maximal effective concentration: 10 nM
Compound 3: the middle estimate sits 25-fold (1.40 log units) above what was measured; the whole stated range lies above it.
By their numbers in this assay, from the lowest: compound 3; then compounds 2 and 1 (each within the scatter of the next).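

In this assay the group on the sulfur turned out to matter: isopropyl in place of methyl gave a 25-fold lower number from compound 2 to compound 3 (1.40 log units; beyond the scatter) and so moved the number far beyond the scatter, which the exchange of methoxy for methylsulfanyl had not done. Isopropylsulfanyl in place of methoxy on the carbonyl carbon gave a 32-fold lower number from compound 1 to compound 3 (1.50 log units; beyond the scatter) as the combined change. Nothing available explains the size of this step.

The compounds shown leave open whether isopropoxy on the same carbonyl carbon would match isopropylsulfanyl, so the part played by the sulfur remains unsettled. They also leave open how tert-butyl, cyclopropyl or a longer chain on the sulfur would compare with isopropyl.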